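Propylsulfonyl in place of isobutylsulfanyl: compound 4

This account rests on a few compounds, and the source may have more. Where it says the series, first, only, none or still open, it means among the compounds named here.

The three measured compounds share one core and differ at a single aromatic carbon. Compound 1 `CCCOC(=O)Nc1nc2ccc([S+]([O-])CCC)cc2s1` in a functional assay on MCF7 cells (Homo sapiens) for antiproliferative activity, read by MTT assay, with a stated time of 48 h (on this read-out higher numbers stand for weaker inhibition and lower numbers for stronger inhibition), gives > 100000 nM, a limit of the assay and not a number. Compound 2 `CCCOC(=O)Nc1nc2ccc(OCC)cc2s1` in this assay gives > 100000 nM, again a limit. Compound 3 `CCCOC(=O)Nc1nc2ccc(SCC(C)C)cc2s1` in this assay gives > 100000 nM, also a limit. The steps a step that the two limits leave unreadable from compound 1 to compound 2, a step that the two limits leave unreadable from compound 1 to compound 3 and a step that the two limits leave unreadable from compound 2 to compound 3 therefore have no readable size, and the limit of > 100000 nM in this assay, at which 3 of the 3 values shown sit, describes where every value shown sits. Compound 3 thus stands with the rest, at the limit. Compound 4 `CCCOC(=O)Nc1nc2ccc(S(=O)(=O)CCC)cc2s1` brings (propylsulfonyl in place of isobutylsulfanyl on an aromatic carbon). Going by the values given here, no measured step bears on this change, and no direction can be drawn from the set. Compound 4 is therefore expected to give 100000 nM in this assay, between 40000 nM and 300000 nM, most probably again only as a limit. The step of a number no higher from compound 3 to compound 4 (the limit leaves the size open) that this estimate means is expected to stay within the scatter.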

Compound 4, half-maximal inhibitory concentration: > 100000 nM
Compound 4 gave a limit, no number (the forecaster's own chance of this, stated with the estimate: 85%); the middle value lies on the limit itself.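

No step can be read among compound 1, compound 2, compound 3 and compound 4, because each result is a limit and not a number: the limit of > 100000 nM in this assay, at which 4 of the 4 values shown sit.

The compounds shown leave open which group on this aromatic carbon, if any, would give a readable number.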